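The source may hold more compounds than are shown below. What is called first, only, known or untested is meant among the compounds shown, and "the series" means these compounds.

Compound 1 `COc1ccc(-c2cncc3[nH]c(=O)n(Cc4cc(OC)c(OC)c(OC)c4)c23)cc1O`: > 20000 nM
Compound 2 `COc1ccc(-c2cc3c(cn2)[nH]c(=O)n3-c2cc(OC)c(OC)c(OC)c2)cc1O`: 490 nM

In a functional assay on HeLa cells (Homo sapiens) for antiproliferative activity, read by MTT assay, with a stated time of 48 h (a higher number here means a weaker inhibitor, a lower number a stronger inhibitor), compound 1 reads > 20000 nM, which is a limit of the assay and not a number. Among the measured compounds shown here, that leaves compound 2, at 490 nM, as the only true number so far. Compound 3 `CCOc1ccc(-c2cc3c(cn2)[nH]c(=O)n3-c2cc(OC)c(OC)c(OC)c2)cc1F` carries 4-ethoxy-3-fluorophenyl in place of 3-hydroxy-4-methoxyphenyl on an aromatic carbon. For the measured compounds named here, no measured pair tests this swap, so only a cautious expectation is possible: a modest weakening in this assay, estimated as a 2.4-fold higher number from compound 2 to compound 3 (0.39 log units; beyond the scatter). Compound 3 is expected at 1200 nM, within an estimated range of 300 nM to 6000 nM.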

Compound 3, half-maximal inhibitory concentration: 2870 nM
For compound 3 the middle estimate is 2.4-fold (0.38 log units) below the measured one; low and high end bracket the measured number.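

In this assay the swap to 4-ethoxy-3-fluorophenyl gives a 5.9-fold higher number from compound 2 to compound 3 (0.77 log units; beyond the scatter) and shows that this position on the shared core responds to the aryl group it carries. Compound 3 still gives a true number, so the swap weakens the compound without taking it to a limit of the assay. Nothing measured here explains the weakening.

The hydroxy, methoxy and fluorine changes arrive together, so the compounds shown cannot separate their contributions. On these data alone, how an amine on this phenyl ring would read also remains open.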